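A Bicyclic Amine in Place of Methylpiperidine

The source may report more compounds than this note shows. Statements on the series, on what has been measured and on what is new or still open speak of the compounds shown alone.

Compound 1, `COc1ccc2[nH]c(C(=O)N3CC(=O)N(Cc4ccccc4)[C@@H](CN4CCC(C)CC4)C3)cc2c1`, was examined in an ADME assay on Vero cells (Chlorocebus sabaeus) for cytotoxicity, with a stated time of 7 days; on this read-out higher numbers stand for lower toxicity in this test and lower numbers for higher toxicity in this test. In this assay compound 1 gives only a limit, > 30000 nM, and not a number. Where compound 1 stands is therefore known just to one side: it sits at the limit of > 30000 nM in this assay, at which 1 of the 2 values shown sits, and nothing more about it can be read from the numbers shown. Compound 2, `Cc1ccc2[nH]c(C(=O)N3CC(=O)N(Cc4ccccc4)[C@@H](CN4CCC5(CCC5)CC4)C3)cc2c1`, carries a different amine and a different substituent on the shared core; in this assay compound 2 gives 7800 nM. Compound 3, `COc1ccc2[nH]c(C(=O)N3CC(=O)N(Cc4ccccc4)[C@@H](CN4CC5CCCCC5C4)C3)cc2c1`, has not yet been measured in this assay. It differs from compound 1 in a single place: a group of 9 heavy atoms (8 carbon, 1 nitrogen; one five-membered non-aromatic ring with 1 hetero atom, one six-membered non-aromatic ring of carbon only) in place of a group of 7 heavy atoms (6 carbon, 1 nitrogen; one six-membered non-aromatic ring with 1 hetero atom), on a saturated chain carbon bound to a saturated ring carbon. Among the measured compounds shown here, no measured pair of compounds differs in one place alone, so no measured step is available to guide the expectation, and the two measured values show only that one lies at the limit while the other is a full number. The step in this assay is expected to be modest and toward lower numbers, an at least 1.6-fold lower number from compound 1 to compound 3 (0.22 log units; that floor lies within the scatter), though a result remaining at the limit would not surprise. The estimated value of compound 3 in this assay is 18000 nM, with a range from 7000 nM to 45000 nM.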

Compound 3, half-maximal cytotoxic concentration: 8200 nM
Compound 3: the middle estimate sits 2.2-fold (0.34 log units) above what was measured; the measured number falls inside the stated range.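

The exchange of the 4-methylpiperidin-1-yl group for the group with one five-membered non-aromatic ring with 1 hetero atom and one six-membered non-aromatic ring of carbon only, on a saturated chain carbon bound to a saturated ring carbon, gives in this assay an at least 3.6-fold lower number from compound 1 to compound 3 (0.56 log units; beyond the scatter) and so moves the read-out beyond the usual scatter. Among the compounds shown here, this is the first step between measured compounds that differ in one place alone, and it shows that the choice of amine at this position by itself changes the number, with the rest of the structure held constant. The true size of the step remains open, and it can be given only as a floor, because compound 1 stands at a limit and not at a number: the limit of > 30000 nM in this assay, at which 1 of the 3 values shown sits.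

The compounds shown do not tell whether the extra ring, the larger group or some other feature of the new amine goes with the lower number, and a morpholine or an open-chain diethylamino group in the same place would help to separate these. Compound 2 differs from compound 1 and from compound 3 in more than one place, so whether the same amine exchange would behave alike with the methyl-bearing core also stays unanswered.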